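The source may hold more compounds than are shown below. What is called first, only, known or untested is meant among the compounds shown, and "the series" means these compounds.

Measured compounds:

Compound 1 `COC(=O)N(C)CC#CCn1cncc1C` gives 5.4 mg/kg in a functional assay on the whole organism for antagonist activity, with Mus musculus as the target; a lower number here means that less compound is needed, a higher number that more compound is needed for the effect.
Compound 3 `CCOC(=O)N(C)CC#CCn1cncc1C` gives 66 mg/kg in this assay.
Compound 2 `CCOC(=O)N(C)CC#CCN1CCCC1` reaches only a limit of this assay, > 100 mg/kg.

Compound 1 and compound 3 share a core and differ by methyl in place of hydrogen on a saturated chain carbon bound to an oxygen next to a carbonyl group. Among the compounds with values here, that step, a 12-fold higher number from compound 1 to compound 3 (1.09 log units; beyond the scatter), is the one measured example of a methyl entering on a saturated chain carbon. The difference between the core of compound 1 and the core of compound 2 is not broken down here.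

Compound 4 `CCOC(=O)N(C)C(C)C#CCN1CCCC1` is not yet measured. It differs from compound 2 by methyl in place of hydrogen on a saturated chain carbon bound to an amide-type nitrogen and a triple-bonded carbon. Within the data shown here, this is the same kind of change as the one from compound 1 to compound 3, but not the same: there the methyl sits on a carbon bound to an oxygen next to a carbonyl group, here on a carbon bound to an amide-type nitrogen and a triple-bonded carbon. Among the measured compounds shown here, the only measured step is a large one towards a higher number, and compound 2 itself sits at the limit (the limit of > 100 mg/kg in this assay, at which 1 of the 3 values shown sits). The expected step that the limit leaves unreadable from compound 2 to compound 4 is therefore taken as unfavourable or flat, and compound 4 is estimated at 200 mg/kg, between 60 mg/kg and 800 mg/kg, with a further limit likely.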

Compound 4, dose for half-maximal effect: > 100 mg/kg
Compound 4 was reported as a limit; the forecaster's own chance of this, stated with the estimate: 75%; the middle value lies beyond the limit too.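

Compound 2 and compound 4 both stand at a limit of this assay, so the step for the methyl on a saturated chain carbon bound to an amide-type nitrogen and a triple-bonded carbon cannot be read: the limit of > 100 mg/kg in this assay, at which 2 of the 4 values shown sit.

The compounds shown leave open whether this methyl changes the dose needed in this assay at all, and in which direction.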